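The compounds below may be only part of what the source reports. "The series", "measured", "known", "first", "only" and "open" are said of these compounds alone.

Of the compounds shown here, two have been measured so far. Compound 1 `CC(C)c1ccc(-n2nc(-c3ccc(C(F)(F)F)cc3O)nc2-c2ccccc2O)cc1` gives 108% in a functional assay on PC-12 cells (Rattus norvegicus) for cytotoxicity, read by MTT assay, with stated times of 2 h and 24 h, tested at 10 uM; a lower number here means a weaker effect, a higher number a stronger effect of the compound at the concentration tested. Compound 2 `Oc1cc(C(F)(F)F)ccc1-c1nc(-c2ccccc2O)n(-c2ccc(Cl)cc2)n1` gives 96.1% in this assay.

Among the measured compounds shown here, on these numbers compound 2 stands lowest of the two, and the single measured step, a number 11.9 percentage points lower from compound 1 to compound 2 (beyond the scatter), lies beyond the scatter. Compound 3 `Oc1cc(C(F)(F)F)ccc1-c1nc(-c2ccccc2O)n(-c2ccc(OC(F)(F)F)cc2)n1` differs from compound 2 in one place: trifluoromethoxy in place of chloro on an aromatic carbon. For the measured compounds named here, the only step that bears on this is a number 11.9 percentage points lower from compound 1 to compound 2 (beyond the scatter); it also concerns a group on an aromatic carbon of the same part of the shared core, and it shifted the number by a modest amount. Going by the values given here, no measured compound carries a trifluoromethoxy group, so the data do not show how this group behaves here. The step is therefore expected to be small, a number 1.1 percentage points lower from compound 2 to compound 3 (within the scatter) in this assay, with no confident direction and most likely within the scatter. Compound 3 is estimated at 95%, with a range from 80% to 110%.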

Compound 3, a percentage reported as activity, at one concentration (the size of the read-out at that concentration, not a potency): 92.5%
Compound 3: middle estimate off by 2.5 percentage points, on the high side; measured number inside the range.
By their numbers in this assay, from the lowest: compounds 3 and 2 (each within the scatter of the next); then compound 1.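

In this assay, trifluoromethoxy in place of chloro on this aromatic carbon, para to a large group, comes to a number 3.6 percentage points lower from compound 2 to compound 3 (within the scatter), so five heavy atoms with one hydrogen-bond acceptor can stand where a single chlorine stood without a step beyond the scatter. Trifluoromethoxy in place of isopropyl at the same place comes to a number 15.5 percentage points lower from compound 1 to compound 3 (beyond the scatter), and with a number 11.9 percentage points lower from compound 1 to compound 2 (beyond the scatter) there are now two modest steps beyond the scatter away from compound 1, one to each of the other groups, so among these three compounds the isopropyl compound is the one that stands apart. Nothing at hand gives a reason for these numbers or tells what the groups do in the cells.

The compounds shown leave open whether a group of another kind at this place, such as an amine, a carboxylic acid or a longer alkyl chain, would stay with chloro and trifluoromethoxy or move the read-out further. They also leave open whether the same small step would hold with any other change on the shared core, since all three compounds differ only at this one place.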